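Dimethylamino versus cyclopropyl(methyl)amino on the shared core

This account rests on a few compounds, and the source may have more. Where it says the series, first, only, none or still open, it means among the compounds named here.

compound 1 `CN(C)c1ncnc2c1ncn2Cc1c(F)cccc1F`: 2.2 mg/kg
compound 2 `CN(c1ncnc2c1ncn2Cc1ccccc1F)C1CC1`: 6.8 mg/kg

In a functional assay on the whole organism with Rattus norvegicus as the target, in the maximal electroshock model (on this read-out higher numbers stand for an effect only at larger amounts of compound and lower numbers for an effect already at smaller amounts), compound 2 gives 6.8 mg/kg, the higher of the two numbers, and its gap to compound 1 lies beyond the scatter. Compound 3 `CN(C)c1ncnc2c1ncn2Cc1ccccc1F` arises from compound 2 by methyl in place of cyclopropyl on a nitrogen on an aromatic ring; the rest of compound 2 is kept. Compound 1 also carries the dimethylamino group and gives 2.2 mg/kg in this assay. Among the measured compounds shown here, no such step has been measured; the step of a 1.9-fold lower number from compound 2 to compound 3 (0.29 log units; within the scatter) is expected to run toward a lower dose, of modest size. Compound 3 is estimated at 3.5 mg/kg, range 1.5 mg/kg to 8 mg/kg.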

Compound 3, dose for half-maximal effect: 8.8 mg/kg
Compound 3: middle estimate off by 2.5-fold (0.40 log units), on the low side; measured number above the stated range.
By their numbers in this assay, from the lowest: compound 1; then compounds 2 and 3 (each within the scatter of the next).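

In this assay, methyl in place of cyclopropyl on the nitrogen gives a 1.3-fold higher number from compound 2 to compound 3 (0.11 log units; within the scatter), so the exchange of cyclopropyl(methyl)amino for dimethylamino has no readable effect on this read-out. The fluoro position does register: hydrogen in place of fluoro on an aromatic carbon gives a 4.0-fold higher number from compound 1 to compound 3 (0.60 log units; beyond the scatter), which separates compound 1 from compound 3 with the dimethylamino group held constant. Nothing at hand explains either step.

From the compounds shown here alone, it remains open whether the nitrogen exchange reads the same with the fluoro pattern of compound 1 in place. Also open, going by these compounds, is how chloro or methoxy on that aromatic carbon, or ethyl on the nitrogen, would read.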